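A few compounds are considered here, and "the series" means these few. Any claim that something is new, unique, unknown or untested is made for them only; others in the source may bear on it.

Among the compounds with values here, compound 1 `COc1ccc(S(=O)(=O)N2CCN(c3ncc(C(=O)NO)s3)CC2)cc1OC` is the only compound here with an actual number. In a functional assay on MCF7 cells (Homo sapiens) for antiproliferative activity (a higher number here means a weaker inhibitor of growth, a lower number a stronger inhibitor of growth), compound 1 gives 2000 nM. Compound 2 `CN1CCN(c2ncc(C(=O)NO)s2)CC1` keeps the same hydroxycarbamoyl group on the shared core but has a much smaller group on its far end. In this assay compound 2 reaches only a limit of the assay, > 100000 nM. That limit of > 100000 nM in this assay, at which 1 of the 2 values shown sits, is where one of the two shown values sits, so compound 1 stands alone as a measured number, with compound 2 as a limit beside it. Within the data shown here, no step between two measured compounds that differ in one place is available, so the size of changes in this assay is not yet known from these data. Compound 3 `COc1ccc(S(=O)(=O)N2CCN(c3ncc(/C=C/C(=O)NO)s3)CC2)cc1OC` is not yet measured; it differs from compound 1 in one place: 2-(hydroxycarbamoyl)ethenyl in place of hydroxycarbamoyl on an aromatic carbon. The hydroxycarbamoyl end is thus pushed further out from the shared core by two carbons of a double bond. Compound 3 is expected to show a step of a 3.3-fold lower number from compound 1 to compound 3 (0.52 log units; beyond the scatter) toward stronger growth inhibition. Compound 3 is therefore estimated at 600 nM, with a range from 150 nM to 2500 nM.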

Compound 3, concentration for 50% growth inhibition: 4000 nM
The estimate for compound 3 lay 6.7-fold (0.82 log units) below the measured number; the measured number lies above the stated range.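

In this assay, within the data shown here, putting 2-(hydroxycarbamoyl)ethenyl in place of hydroxycarbamoyl gives a 2.0-fold higher number from compound 1 to compound 3 (0.30 log units; within the scatter), the first step between two measured compounds that differ in one place. It shows that at this position, on an aromatic carbon next to the ring sulfur, this change in the group's length produces no difference that can be told from the ordinary spread of repeated measurements, so compound 1 and compound 3 cannot be ranked against each other in this assay. Nothing measured here explains why the two compounds cannot be told apart, and this single pair cannot show how far the result extends to other groups at this position.

From the compounds shown here alone, it remains open whether a carboxylic acid in place of hydroxycarbamoyl, or a longer chain ending in hydroxycarbamoyl, would also leave the number within the scatter of compound 1. Going by these compounds, it is equally open whether 2-(hydroxycarbamoyl)ethenyl would give the same result on a core carrying a different group at its far end, such as a simple benzoyl in place of the sulfonyl-linked dimethoxyphenyl of compound 1.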